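Swapping the distal aryl ring in a fatty acid receptor series

The source may hold more compounds than are shown below. What is called first, only, known or untested is meant among the compounds shown, and "the series" means these compounds.

Compound 1 `CCc1ccccc1-c1cccc(COc2ccc([C@H](CC(=O)O)c3nccn3C)cc2)c1`: 48 nM
Compound 2 `COc1ccccc1-c1cccc(COc2ccc([C@H](CC(=O)O)c3nccn3C)cc2)c1`: 410 nM

In an assay on CHO cells for agonist activity at Free fatty acid receptor 1 (Homo sapiens), read by luminescence, with a stated time of 20 s, in the presence of a further agent that is not named here (on this read-out higher numbers stand for an effect only at larger amounts of compound and lower numbers for an effect already at smaller amounts), compound 2 gives the highest of the two numbers measured; its nearest neighbour, compound 1, differs by an 8.5-fold higher number from compound 1 to compound 2 (0.93 log units; beyond the scatter). Compound 3 `Cn1ccnc1[C@@H](CC(=O)O)c1ccc(OCc2cccc(-c3ccc(Cl)cc3Cl)c2)cc1` is not yet measured. It differs from compound 2 by 2,4-dichlorophenyl in place of 2-methoxyphenyl on an aromatic carbon. Within the data shown here, the only step that bears on this exchange is an 8.5-fold higher number from compound 1 to compound 2 (0.93 log units; beyond the scatter), which shows that the group at this place moves the number well beyond the scatter. Compound 3 is therefore expected to give a lower number, a 5.1-fold lower number from compound 2 to compound 3 (0.71 log units; beyond the scatter), with an estimate of 80 nM in a range from 25 nM to 300 nM.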

Compound 3, half-maximal effective concentration: 69 nM
Beside the measured number, compound 3's estimate is 1.2-fold (0.06 log units) above it, within the range that was stated.
By their numbers in this assay, from the lowest: compounds 1 and 3 (each within the scatter of the next); then compound 2.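

In this assay, 2,4-dichlorophenyl at this place gives a much lower number than 2-methoxyphenyl (a 5.9-fold lower number from compound 2 to compound 3 (0.77 log units; beyond the scatter)) and stays level with the 2-ethylphenyl of compound 1 (a 1.4-fold higher number from compound 1 to compound 3 (0.16 log units; within the scatter)). The place therefore accepts a ring bearing two chlorines as well as it accepts 2-ethylphenyl, and among the three compounds only the 2-methoxyphenyl of compound 2 stands apart. No evidence is given that would account for this difference. Which of the two chlorines matters remains open, as does whether trifluoromethyl or a nitrile on this ring would give a similar number.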